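Series notes on the benzylamide side chain

This account rests on a few compounds, and the source may have more. Where it says the series, first, only, none or still open, it means among the compounds named here.

Three benzylamides of one shared core have been run in a functional assay on the whole organism (strain NMRI) with Mus musculus as the target, in the maximal electroshock model, with a stated time of 30 min; a higher number here means that more compound is needed for the effect, a lower number that less compound is needed. Compound 1 `CCCC(N)C(=O)NCc1ccccc1` gives 39 mg/kg in this assay. Compound 2 `CC(C)(C)[C@@H](N)C(=O)NCc1ccccc1` gives 13 mg/kg, and compound 3 `CSCC[C@@H](N)C(=O)NCc1ccccc1` gives 75 mg/kg. Compound 1 therefore stands second highest of the three numbers: its gap to compound 3 lies within the scatter, while compound 2 sits at a lower number by more than the scatter. For the measured compounds named here, the single step computed so far, a 5.8-fold higher number from compound 2 to compound 3 (0.76 log units; beyond the scatter), shows that an exchange of the side chain alone can move the read-out by a modest amount.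

The next compound, compound 4 `CN(C)CC(N)C(=O)NCc1ccccc1`, differs from compound 1 by dimethylamino in place of ethyl on a saturated chain carbon, two bonds along the chain from an amine nitrogen and a carbonyl carbon. Going by the values given here, no measured pair covers this exchange; the only available step, a 5.8-fold higher number from compound 2 to compound 3 (0.76 log units; beyond the scatter), concerns a different pair of groups at the same kind of position and so gives a guide to the scale of side-chain effects, not to their direction here. A step in this assay within the scatter or a modest rise is expected for compound 4, and the estimated step is a 1.4-fold higher number from compound 1 to compound 4 (0.15 log units; within the scatter). Compound 4 is thus expected to give about 55 mg/kg in this assay, with a range from 20 mg/kg to 150 mg/kg.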

Compound 4, dose for half-maximal effect: 94 mg/kg
The estimate for compound 4 lay 1.7-fold (0.23 log units) below the measured number, within the range that was stated.
By their numbers in this assay, from the lowest: compound 2; then compounds 1, 3 and 4 (each within the scatter of the next, the first and the last beyond it).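

In this assay, dimethylamino in place of ethyl on a saturated chain carbon, two bonds along the chain from an amine nitrogen and a carbonyl carbon, gives a 2.4-fold higher number from compound 1 to compound 4 (0.38 log units; beyond the scatter) and so fixes a direction for this exchange, which the earlier pair could not supply. The step is modest and points to a higher number, as does a 5.8-fold higher number from compound 2 to compound 3 (0.76 log units; beyond the scatter) on the other pair, but the groups exchanged differ, so the two steps together set no rule for the position. Nothing measured on these compounds gives a reason for the step from ethyl to dimethylamino.

The compounds shown leave open whether the step follows the nitrogen of dimethylamino or simply the larger group, a question that isopropyl on the same saturated chain carbon would help to separate. Also open, going by these compounds, is how a methoxy group, a carboxylic acid or a longer chain bearing dimethylamino would read at that carbon, and whether the same exchange gives a step of similar size on the side chains of the other compounds.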